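Diaminoquinoxaline series: sulfanyl-to-benzylamino replacement on the core

The source may report more compounds than this note shows. Statements on the series, on what has been measured and on what is new or still open speak of the compounds shown alone.

Compound 1 `Nc1cc(N)c2nc(-c3ccccc3)c(Sc3ccc(F)cc3)nc2c1` gives 22900 nM in a functional assay on LOX IMVI cells (Homo sapiens) for inhibition, read by sulforhodamine B assay, with a stated time of 48 h; on this read-out higher numbers stand for weaker inhibition of growth and lower numbers for stronger inhibition of growth.
Compound 2 `COc1cc(CNc2nc3cc(N)cc(N)c3nc2-c2ccccc2)cc(OC)c1OC` gives 3160 nM in this assay.

Compound 1 has the highest number of the two; compound 2 lies beyond the scatter from it. Compound 3 `Nc1cc(N)c2nc(-c3ccccc3)c(NCc3ccc(F)cc3)nc2c1` differs from compound 1 by (4-fluorobenzyl)amino in place of (4-fluorophenyl)sulfanyl on an aromatic carbon. Among the compounds with values here, no step between measured compounds isolates this change, but compound 2, which carries a benzylamino group on the shared core, gives 3160 nM, well under compound 1. The step of a 4.6-fold lower number from compound 1 to compound 3 (0.66 log units; beyond the scatter) is therefore expected to be downward and beyond the scatter. Compound 3 is estimated at 5000 nM, within 1500 nM to 15000 nM.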

Compound 3, concentration for 50% growth inhibition: 1510 nM
Compound 3: the middle estimate sits 3.3-fold (0.52 log units) above what was measured, and the stated range covers the measured number.
By their numbers in this assay, from the lowest: compound 3; then compound 2; then compound 1.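

At this position, on an aromatic carbon next to the ring nitrogen, (4-fluorobenzyl)amino in place of (4-fluorophenyl)sulfanyl gives a 15-fold lower number from compound 1 to compound 3 (1.18 log units; beyond the scatter) in this assay as a direct reading of this change. The fluorinated ring stands on both sides of the step, so the step follows the link that carries it, though the sulfur and the added carbon change together. Nothing measured here explains the step.

On these data alone, whether the amine nitrogen or the added carbon drives the step stays open. A (4-fluorophenyl)amino group or a (4-fluorobenzyl)sulfanyl group would separate the two, and a longer chain would test the link length.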